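The source may hold more compounds than are shown below. What is called first, only, known or untested is meant among the compounds shown, and "the series" means these compounds.

In a functional assay on HeLa cells (Homo sapiens) for antiproliferative activity, read by MTT assay, with a stated time of 72 h (a higher number here means a weaker inhibitor, a lower number a stronger inhibitor), compound 3 (`CC/C=C/C(=O)Nc1cccc(Oc2nc(Nc3ccc(OC)nc3)nc3c2CSCC3)c1`) gives 31200 nM as its value. That lies within the usual scatter of compound 1 (`CCC/C=C/C(=O)Nc1cccc(Oc2nc(Nc3ccn(C)n3)nc3c2CSCC3)c1`), which gives 17000 nM in the same read-out, and it is a higher number than compound 2 (`CCC/C=C/C(=O)Nc1cccc(Oc2nc(Nc3cccc(C#N)c3)nc3c2CSCC3)c1`) with 7220 nM as its value. Compound 4 (`CCC/C=C/C(=O)Nc1cccc(Oc2nc(Nc3ccc(OC)nc3)nc3c2CSCC3)c1`) differs from compound 3 as follows (methyl in place of hydrogen on a saturated chain carbon, two bonds along the chain from a double-bonded chain carbon): methyl in place of hydrogen on a saturated chain carbon, two bonds along the chain from a double-bonded chain carbon, so that but-1-en-1-yl becomes pent-1-en-1-yl. Going by the values given here, the one measured step (a 2.4-fold lower number from compound 1 to compound 2 (0.37 log units; beyond the scatter)) is modest and replaces a group on a nitrogen on an aromatic ring, not the chain. Among the compounds with values here, no measured pair therefore isolates this chain change, and no step beyond the scatter is expected in this assay from it. For compound 4 the estimated value is 23000 nM (expected range 10000 nM to 50000 nM). This estimate means an expected change (a 1.4-fold lower number from compound 3 to compound 4 (0.13 log units; within the scatter)) that stays within the scatter.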

Compound 4, half-maximal inhibitory concentration: 15300 nM
Compound 4: middle estimate off by 1.5-fold (0.18 log units), on the high side, and the stated range covers the measured number.
By their numbers in this assay, from the lowest: compound 2; then compounds 4, 1 and 3 (each within the scatter of the next, the first and the last beyond it).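

In this assay, going by these compounds alone, the chain gives the first measured step at this position: but-1-en-1-yl becoming pent-1-en-1-yl brings a modest change (a 2.0-fold lower number from compound 3 to compound 4 (0.31 log units; beyond the scatter)) that lies beyond the scatter, so the saturated chain carbon two bonds along the chain from a double-bonded chain carbon does register in this pair. With pent-1-en-1-yl held, 6-methoxypyridin-3-yl in place of 3-cyanophenyl also gives a modest step beyond the scatter (a 2.1-fold higher number from compound 2 to compound 4 (0.33 log units; beyond the scatter)), while 6-methoxypyridin-3-yl in place of 1-methyl-1H-pyrazol-3-yl stays within it (a 1.1-fold lower number from compound 1 to compound 4 (0.05 log units; within the scatter)). No measured evidence accounts for these steps.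

As far as these compounds go, this is a single chain pair, so whether hex-1-en-1-yl or a chain ending in an amine would extend the step stays open. Also open, from the compounds shown here alone, is whether the same chain change holds with 3-cyanophenyl on the nitrogen.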